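Oxadiazole sulfonamides at the EP1 receptor: a benzyl-to-aryloxy swap

The source may report more compounds than this note shows. Statements on the series, on what has been measured and on what is new or still open speak of the compounds shown alone.

Measured compounds:
compound 1 `CCc1ccccc1N(Cc1nnc(Cc2ccccc2)o1)S(=O)(=O)c1ccc(C)cc1` gives 398 nM
compound 2 `Cc1ccc(S(=O)(=O)N(Cc2nnc(Cc3ccc(N(C)C)cc3)o2)c2cccc(Cl)c2C)cc1` gives 20 nM

In a functional assay on CHO cells for antagonist activity at prostaglandin E2 receptor EP1 subtype (Homo sapiens), read by FLIPR and calcium flux (on this read-out higher numbers stand for weaker inhibition and lower numbers for stronger inhibition), compound 1 stands at the highest of the two numbers; compound 2 sits well below it, but the two differ in more than one place, so no single change accounts for that gap.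

Compound 3 `CCc1ccccc1N(Cc1nnc(Oc2ccc(OC)cc2)o1)S(=O)(=O)c1ccc(C)cc1` differs from compound 1 by 4-methoxyphenoxy in place of benzyl on an aromatic carbon. Among the compounds with values here, no measured pair isolates this change, so the size of the step is open. The expectation is that the step of a 1.2-fold lower number from compound 1 to compound 3 (0.09 log units; within the scatter) stays within the usual scatter, with no clear direction. Compound 3 is estimated at 320 nM, with a range from 80 nM to 1300 nM.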

Compound 3, inhibition constant: 100 nM
The estimate for compound 3 lay 3.2-fold (0.51 log units) above the measured number; the measured number falls inside the stated range.
By their numbers in this assay, from the lowest: compound 2; then compound 3; then compound 1.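

In this assay, 4-methoxyphenoxy in place of benzyl on an aromatic carbon of the five-membered aromatic ring gives a 4.0-fold lower number from compound 1 to compound 3 (0.60 log units; beyond the scatter), a modest step. Within the data shown here, this is the first single-place comparison, and it shows that the read-out responds to the group at this position. No available data bear on the reason for this step.

The ether oxygen and the methoxy enter together, so their separate contributions remain unresolved. Also open, on these data alone, is how a carboxylic acid or an amine at this position would compare.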